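Working notes: filling the open core position

A few compounds are considered here, and "the series" means these few. Any claim that something is new, unique, unknown or untested is made for them only; others in the source may bear on it.

Measured so far:
- compound 1 `CCN1CCN(CCCn2cnc3c(N4CCN(CC)CC4)nc(N)nc32)CC1`; in an assay on HEK293 cells for antagonist activity at Toll-like receptor 9 (Homo sapiens), read by spectrophotometry (a higher number here means a weaker inhibitor, a lower number a stronger inhibitor), compound 1 gives 260 nM
- compound 2 `CCN1CCN(CCCn2cnc3c(N4CCN(CC)CC4)ncnc32)CC1`; in this assay compound 2 gives 1190 nM
- compound 3 `CCN1CCN(c2nc(NCc3ccc(CN(C)C)cc3)nc3c2ncn3CCCN2CCCC2)CC1`; in this assay compound 3 gives 90 nM

Compound 2 carries the highest number of the three. Compound 1 is its nearest neighbour and compound 3 its furthest, and both gaps lie beyond the scatter.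

Among the measured compounds shown here, the one single-point step recorded here is a 4.6-fold higher number from compound 1 to compound 2 (0.66 log units; beyond the scatter): taking the amino off that aromatic carbon raises the number. Compound 3 carries a substituted benzylamino group at the same carbon and gives the lowest number of the set, but it also differs from compound 2 in its chain, so only its value can be compared, not a clean step.

Compound 4 `CCN1CCN(CCCn2cnc3c(N4CCN(CC)CC4)nc(NCc4ccc(OC)cc4)nc32)CC1` is compound 2 with (4-methoxybenzyl)amino in place of hydrogen on an aromatic carbon. The step from compound 1 to compound 2 bears on it directly, in reverse: restoring a nitrogen substituent at this carbon is expected to lower the number in this assay, and the value of compound 3 at 90 nM suggests a benzylamino group can do more than a bare amino.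

For compound 4 the expected step is a 17-fold lower number from compound 2 to compound 4 (1.23 log units; beyond the scatter), giving an estimate of 70 nM with a range from 25 nM to 200 nM.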

Compound 4, half-maximal inhibitory concentration: 200 nM
Compound 4: the middle estimate sits 2.9-fold (0.46 log units) below what was measured, within the range that was stated.
By their numbers in this assay, from the lowest: compound 3; then compounds 4 and 1 (each within the scatter of the next); then compound 2.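

In this assay, the aromatic carbon between two ring nitrogen atoms accepts (4-methoxybenzyl)amino in place of hydrogen, with a 6.0-fold lower number from compound 2 to compound 4 (0.77 log units; beyond the scatter) on this change, so the gain seen with a bare amino is not confined to that small group. Against the bare amino itself, adding 4-methoxybenzyl on that nitrogen gives a 1.3-fold lower number from compound 1 to compound 4 (0.11 log units; within the scatter) in this pair, so the two nitrogen substituents cannot be told apart and the benzyl part shows no separate contribution here. No independent data are available on why these two substituents read alike.

From the compounds shown here alone, it remains open whether a plain benzylamino group, a methylamino group or a longer chain such as phenethylamino on this nitrogen would separate from the bare amino, and whether a carboxylic acid on the benzyl ring would do so. Compound 3 gives 90 nM with both a different chain on the ring nitrogen and a different benzyl substituent, so that value cannot be assigned to either change from the compounds shown.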